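The source may hold more compounds than are shown below. What is called first, only, known or untested is meant among the compounds shown, and "the series" means these compounds.

Compound 2 `O=C1/C(=C/c2ccccc2F)CN(Cc2cn(Cc3ccccc3Cl)nn2)C/C1=C\c1ccccc1F` and compound 1 `O=C1/C(=C/c2ccccc2F)CN(Cc2cn(Cc3ccccc3F)nn2)C/C1=C\c1ccccc1F` are built on one shared core and differ by fluoro in place of chloro on an aromatic carbon. In a functional assay on DU-145 cells (Homo sapiens) for cytotoxicity, read by MTT assay, with a stated time of 24 h (on this read-out higher numbers stand for weaker inhibition and lower numbers for stronger inhibition), compound 2 gives 7500 nM, and compound 1 gives 10600 nM, so that there is a 1.4-fold higher number from compound 2 to compound 1 (0.15 log units; within the scatter). Compound 3 `COc1ccc(/C=C2\CN(Cc3cn(Cc4ccccc4Cl)nn3)C/C(=C\c3ccc(OC)cc3)C2=O)cc1` rests on a different core; the difference between the two cores is not broken down here. In this assay compound 3 gives 17800 nM. Compound 4 `COc1ccc(/C=C2\CN(Cc3cn(Cc4ccccc4F)nn3)C/C(=C\c3ccc(OC)cc3)C2=O)cc1` stands to compound 3 as compound 1 stands to compound 2, carrying (fluoro in place of chloro on an aromatic carbon). For compound 4 a step of similar size is expected, namely a 1.2-fold higher number from compound 3 to compound 4 (0.09 log units; within the scatter), because the same change gave a 1.4-fold higher number from compound 2 to compound 1 (0.15 log units; within the scatter); this rests on a single measured pair on another core. Compound 4 is therefore estimated at 22000 nM in this assay, with a range from 11000 nM to 45000 nM.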

Compound 4, half-maximal inhibitory concentration: 32600 nM
The estimate for compound 4 lay 1.5-fold (0.17 log units) below the measured number; low and high end bracket the measured number.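

Swapping chloro for fluoro on the aromatic carbon gives, in this assay, a 1.8-fold higher number from compound 3 to compound 4 (0.26 log units; within the scatter). Set beside the earlier step, the change reads alike on both cores: the same change on two cores in this assay, a 1.4-fold higher number (0.15 log units; within the scatter) from compound 2 to compound 1 and a 1.8-fold higher number (0.26 log units; within the scatter) from compound 3 to compound 4, 1.3-fold (0.11 log units) apart, within the scatter of two such steps. This shows that the change carried from one core to the other without a detectable difference on these two cores, but it does not show that fluoro and chloro differ in this assay, since each step lies within the scatter, and two cores cannot speak for others in the series.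

On these data alone, it remains open how a bromo, a methyl or a methoxy group on the same aromatic carbon would read. Also open, as far as these compounds go, is whether a plain benzyl group would stay in line with the 2-chlorobenzyl and 2-fluorobenzyl compounds.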